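The source may hold more compounds than are shown below. What is called first, only, known or untested is meant among the compounds shown, and "the series" means these compounds.

Compound 1 `C/C(=N\OCCF)c1ccc(Sc2cc(F)cc(C3CCOCC3)c2)cc1` carries a fluoromethyl group on a saturated chain carbon bound to an oxygen. In a functional assay (blood) for inhibition, with Homo sapiens as the target (a higher number here means a weaker inhibitor, a lower number a stronger inhibitor), compound 1 gives 40 nM. Compound 2 `CO[C@]1(c2cnc(Sc3ccc(/C(C)=N/OCC#N)cc3)s2)CCO[C@@H](C)C1`, built on a different core, reaches 40 nM in this assay; compound 1 and compound 2 agree at the digits shown, so their readings sit within the ordinary scatter of repeated measurements and neither can be called the stronger inhibitor. Within the data shown here, no pair of measured compounds differs in only one place, so no measured step is available to lean on. Compound 3 `C/C(=N\OCC#N)c1ccc(Sc2cc(F)cc(C3CCOCC3)c2)cc1` has not yet been tested in this assay; it differs from compound 1 in a single place: cyano in place of fluoromethyl on a saturated chain carbon bound to an oxygen. The group that enters is the same cyanomethoxy group already present in compound 2, and compound 2 shows 40 nM with it. Compound 3 is therefore expected to land near 40 nM, with a plausible range from 15 nM to 110 nM. The expected step of no change at the digits printed from compound 1 to compound 3 (within the scatter) is small, likely not beyond the usual scatter, and its direction cannot be told from these two compounds alone.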

Compound 3, half-maximal inhibitory concentration: 20 nM
The estimate for compound 3 lay 2.0-fold (0.30 log units) above the measured number; the measured number falls inside the stated range.
By their numbers in this assay, from the lowest: compounds 3, 1 and 2 (each within the scatter of the next).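

In this assay, among these compounds, this is the first comparison between two compounds that differ in only one place: cyano in place of fluoromethyl on a saturated chain carbon bound to an oxygen gives a 2.0-fold lower number from compound 1 to compound 3 (0.30 log units; within the scatter). On the shared core, then, the 2-fluoroethoxy and cyanomethoxy groups cannot be told apart by this read-out, even though the exchange replaces a fluorine-bearing end with a nitrile and adds one hydrogen-bond acceptor by the count. No measurement bears on why the two compounds read alike, and the result offers no explanation at the level of the groups themselves.

On these data alone, whether this position would keep its reading with a quite different group, such as an amine, a carboxylic acid or a longer chain, remains open. Also open, as far as these compounds go, is whether the same exchange from fluoromethyl to cyano would read the same way on another core, such as that of compound 2, as this single pair speaks only for the core it shares.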